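Trifluoromethyl in place of methyl on compound 1

This account rests on a few compounds, and the source may have more. Where it says the series, first, only, none or still open, it means among the compounds named here.

In a functional assay on MCF7 cells (Homo sapiens) for antiproliferative activity, read by MTT assay, with a stated time of 48 h (a higher number here means a weaker inhibitor, a lower number a stronger inhibitor), compound 1 (`COc1ccc(-c2nnc(NC(=O)/C=C/c3ccc(C)cc3)s2)cc1`) gives 0.31 ug/mL, compound 2 (`Cc1ccc(/C=C/C(=O)Nc2nnc(-c3ccc(C)cc3)s2)cc1`) gives 0.61 ug/mL and compound 3 (`Cc1ccc(/C=C/C(=O)Nc2nnc(-c3ccc(Br)cc3)s2)cc1`) gives 1.32 ug/mL. Compound 1 sits at the low end of this small set, although it cannot be separated from compound 2, as the first step below shows.

The next compound is compound 4 (`COc1ccc(-c2nnc(NC(=O)/C=C/c3ccc(C(F)(F)F)cc3)s2)cc1`), which carries trifluoromethyl in place of methyl on an aromatic carbon. For the measured compounds named here, compounds 1, 2 and 3 all keep the methyl that leaves here, so no measured step tests this change directly.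

The nearest guide is the size of the steps made by swapping a single substituent elsewhere in the series: a 2.0-fold higher number from compound 1 to compound 2 (0.29 log units; within the scatter), then a 4.3-fold higher number from compound 1 to compound 3 (0.63 log units; beyond the scatter), and a 2.2-fold higher number from compound 2 to compound 3 (0.34 log units; beyond the scatter). These steps are modest or smaller, and each goes towards a higher number when methoxy or methyl is replaced. They are only indirect evidence for the direction of a change at a different place.

A small move towards a higher number in this assay is therefore expected, probably not clearly beyond the scatter. The expected step is a 1.6-fold higher number from compound 1 to compound 4 (0.21 log units; within the scatter). For compound 4 the estimated value is 0.5 ug/mL, with an expected range from 0.15 ug/mL to 1.6 ug/mL.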

Compound 4, half-maximal inhibitory concentration: 0.79 ug/mL
Estimate against measurement, compound 4: 1.6-fold (0.20 log units) below, and the stated range covers the measured number.
By their numbers in this assay, from the lowest: compounds 1, 2, 4 and 3 (each within the scatter of the next, the first and the last beyond it).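

For the compounds shown here, this is the first reading at the position that the earlier steps left untouched. In this assay, trifluoromethyl in place of methyl on an aromatic carbon, para to a large group, gives a 2.5-fold higher number from compound 1 to compound 4 (0.41 log units; beyond the scatter), so a change at this place moves the number beyond the scatter, and the step is modest rather than large even though four heavy atoms enter where one leaves. Compound 4 stays measurable at 0.79 ug/mL, which shows that this position accepts a group larger than methyl with only a modest cost, though nothing measured on these compounds accounts for the step.

As far as these compounds go, one pair sets no trend at this place, and it remains open whether a chloro, a methoxy, an amine or a carboxylic acid there would move the number up or down relative to methyl. Going by these compounds alone, it is also open whether the step from methyl to trifluoromethyl keeps its size when the methoxy of compound 1 gives way to the methyl of compound 2 or the bromo of compound 3, since the two places have not yet been read together.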